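Replacing the Cyclopropylmethyl Group of Compound 3

This account rests on a few compounds, and the source may have more. Where it says the series, first, only, none or still open, it means among the compounds named here.

Measured so far in an assay for inhibition of kynurenine 3-monooxygenase (Homo sapiens), read by mass spectrometry, with a stated time of 1 h; a lower number here means a stronger inhibitor, a higher number a weaker inhibitor:
compound 1 `Cc1ccc([C@@H](C)Oc2cc3oc(=O)n(CCC(=O)O)c3cc2Cl)nc1` — 3.16 nM
compound 2 `O=C(O)CCn1c(=O)oc2cc(OCc3ccccn3)c(Cl)cc21` — 3.16 nM
compound 3 `O=C(O)CCn1c(=O)oc2cc(OCC3CC3)c(Cl)cc21` — 10 nM

Compound 3 gives the highest number of the three. Its nearest neighbour is compound 1, whose number is lower by a margin beyond the scatter, and compound 2 sits at the same value as compound 1. Compounds 1 and 2 are within the scatter of each other, so no order can be claimed between them.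

The step to compound 4 `C[C@@H](Oc1cc2oc(=O)n(CCC(=O)O)c2cc1Cl)c1ncco1` changes the group on the aromatic oxygen: a group of 7 heavy atoms (5 carbon, 1 nitrogen, 1 oxygen; one five-membered aromatic ring with 2 hetero atoms) in place of a group of 4 heavy atoms (4 carbon; one three-membered non-aromatic ring of carbon only), on an oxygen on an aromatic ring. Among the compounds with values here, one measured step bears on this: a 3.2-fold higher number from compound 2 to compound 3 (0.50 log units; beyond the scatter), where a saturated ring replaced an aromatic heterocycle and the number rose. The present change runs the other way, putting an aromatic heterocycle back in place of the saturated ring, while also adding a stereocentre and a branching methyl as in compound 1. Both heterocycle-bearing compounds, compound 1 and compound 2, sit at the same lower value, so a step back down of comparable size is expected, with a 2.9-fold lower number from compound 3 to compound 4 (0.46 log units; beyond the scatter) in this assay.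

Compound 4 is therefore estimated at 3.5 nM, with a likely range from 1.5 nM to 10 nM.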

Compound 4, half-maximal inhibitory concentration: 3.16 nM
Compound 4: middle estimate off by 1.1-fold (0.04 log units), on the high side; measured number inside the range.
By their numbers in this assay, from the lowest: compounds 1, 2 and 4 (each within the scatter of the next); then compound 3.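

In this assay, an aromatic ring with a different size and hetero atom count also works on this oxygen: the 1,3-oxazol-2-yl group, carried on a saturated chain carbon, gives a 3.2-fold lower number from compound 3 to compound 4 (0.50 log units; beyond the scatter). Against the compounds bearing six-membered aromatic rings, there is no change at the digits printed from compound 2 to compound 4 (within the scatter) and also no change at the digits printed from compound 1 to compound 4 (within the scatter), so exchanging the six-membered ring for the five-membered one, with its 2 hetero atoms, leaves the number where it was. Of the four compounds, the three bearing an aromatic heterocycle share one value, and only compound 3, with its three-membered non-aromatic ring, stands apart.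

The step to compound 4 brings in the aromatic ring, the branching methyl and the defined stereocentre together, so the compounds shown cannot say which of these accounts for the lower number, nor whether a plain phenyl ring or a 1,3-thiazol-2-yl group on the same carbon would sit at the same value. No measurement shown here offers an explanation for the step from the cyclopropylmethyl group or for the flat values among the heterocycles.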